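This account rests on a few compounds, and the source may have more. Where it says the series, first, only, none or still open, it means among the compounds named here.

Measured compounds and values:
- compound 1, `COc1ccc(/C=C/C(=O)c2ccc(OC)c3c2OC(C)(C)C=C3)c(F)c1`, gives 6570 nM in a functional assay on SW-620 cells (Homo sapiens) for antiproliferative activity, read by MTT assay, with a stated time of 24 h; a lower number here means a stronger inhibitor, a higher number a weaker inhibitor.
- compound 2, `COc1ccc(C(=O)/C=C/c2cccc(F)c2)c2c1C=CC(C)(C)O2`, gives > 10000 nM in this assay; this is a limit of the assay, not a measured number.

Compound 2 therefore stands only at the limit of > 10000 nM in this assay, at which 1 of the 2 values shown sits, so its true value is known only as lying past that limit. Among the compounds with values here, the one measured step, an at least 1.5-fold higher number from compound 1 to compound 2 (0.18 log units; that floor lies within the scatter), exchanged the whole ring on the chain and ended in that limit, so its full size is not known either. Compound 3, `COc1ccc(C(=O)/C=C/c2cccc(C(F)(F)F)c2)c2c1C=CC(C)(C)O2`, differs from compound 2 in a single place: trifluoromethyl in place of fluoro on an aromatic carbon. Within the data shown here, no measured step in this set swaps fluoro for trifluoromethyl, so nothing here points to a direction for this change, and no step beyond the usual scatter is expected from it. Starting from a limit, the most likely outcome is that compound 3 again gives only a limit. For compound 3 the estimate in this assay is 15000 nM, with a range from 5000 nM to 50000 nM. This estimate amounts to an expected step that the limit leaves unreadable from compound 2 to compound 3.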

Compound 3, half-maximal inhibitory concentration: 7870 nM
Estimate against measurement, compound 3: 1.9-fold (0.28 log units) above; the range from low to high includes it.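

In this assay, exchanging fluoro for trifluoromethyl on this aromatic carbon gives an at least 1.2-fold lower number from compound 2 to compound 3 (0.10 log units; that floor lies within the scatter). Compound 3 gives 7870 nM, a measured number, so on this ring a group of 4 heavy atoms in place of 1 does not take the compound out of the measurable range. The true size of the step remains unknown because compound 2 carries only a limit: the limit of > 10000 nM in this assay, at which 1 of the 3 values shown sits.

The compounds shown leave open whether trifluoromethyl really differs from fluoro at this position, and whether the same exchange would act in the same way in another compound, since this single pair sets no pattern. They also leave open what an amine, a carboxylic acid or a nitrile would do on this same aromatic carbon, and whether any group placed here can bring a step that clearly exceeds the usual scatter of this kind of measurement.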